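The compounds below may be only part of what the source reports. "The series", "measured", "known", "first", "only" and "open" are said of these compounds alone.

Working notes on the series. Among the compounds with values here, in a functional assay on MCF7 cells (Homo sapiens) for cytotoxicity, read by sulforhodamine B assay (on this read-out higher numbers stand for an effect only at larger amounts of compound and lower numbers for an effect already at smaller amounts), compound 1 (`COc1cccc(C2CC(=O)c3ccccc3N2)c1`) gives 0.32 ug/mL and compound 2 (`COc1cccc(C2CC(=O)c3cc(N4CCCC4)ccc3N2)c1`) gives 0.11 ug/mL, the lowest of the two numbers so far. Next comes compound 3 (`O=C1CC(c2cccc(Cl)c2)Nc2ccc(N3CCCC3)cc21`), which keeps the pyrrolidin-1-yl group of compound 2 and carries chloro in place of methoxy on an aromatic carbon. Within the data shown here, only one measured step is available, a 2.9-fold lower number from compound 1 to compound 2 (0.46 log units; beyond the scatter), a modest change made at a different place on the structure. Among the measured compounds shown here, it gives a rough scale for the series but no direct precedent for this exchange, and no measured compound carries chloro. In this assay, from the compounds shown here alone, the estimated change is a 1.1-fold higher number from compound 2 to compound 3 (0.04 log units; within the scatter), so no step beyond the scatter is expected, and the direction remains open. For compound 3 the expected value is 0.12 ug/mL, with an estimated range from 0.04 ug/mL to 0.36 ug/mL.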

Compound 3, concentration for half-maximal effect: 0.31 ug/mL
The estimate for compound 3 lay 2.6-fold (0.41 log units) below the measured number, and the stated range covers the measured number.
By their numbers in this assay, from the lowest: compound 2; then compounds 3 and 1 (each within the scatter of the next).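

In this assay, within the data shown here, the step from 3-methoxyphenyl to 3-chlorophenyl gives a 2.8-fold higher number from compound 2 to compound 3 (0.45 log units; beyond the scatter), the first reading at this position, and it shows that the read-out responds to this exchange on the aromatic ring when the pyrrolidin-1-yl group is present. The step runs in the opposite direction to a 2.9-fold lower number from compound 1 to compound 2 (0.46 log units; beyond the scatter), which was made at a different place on the structure, so changes at both places move the number beyond the scatter. No measured data bearing on the reason for the new step are available.

Among these compounds, whether the same exchange gives a step of this size on the core without the pyrrolidin-1-yl group remains open, since this single pair is the only reading of it. Also open, from the compounds shown here alone, is how other groups at this position, such as hydroxyl, fluoro or an amine, would read compared with methoxy and chloro.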